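From Compound 1 to Compound 4 in a Cell Inhibition Assay

A few compounds are considered here, and "the series" means these few. Any claim that something is new, unique, unknown or untested is made for them only; others in the source may bear on it.

Measured compounds:
compound 1, `COc1cc(NC(=O)Nc2cc(Nc3ccc(OC)c(I)c3)ncn2)cc(OC)c1`, 47.1%
compound 2, `CC(C)(C)c1cccc(Nc2cc(NC(=O)Nc3c(Cl)cccc3Cl)ncn2)c1`, 87.1%
compound 3, `COc1cc(NC(=O)Nc2cc(Nc3cc(C(F)(F)F)ccc3OC)ncn2)cc(OC)c1`, 81.1%

In a functional assay on PC-9 cells (Homo sapiens) for inhibition, read by MTT assay, with a stated time of 48 h, tested at 10 uM (a lower number here means less inhibition, a higher number more inhibition at the concentration tested (going by the name of the read-out)), compound 1 gives 47.1%, the lowest of the three numbers. Its nearest neighbour is compound 3, which gives 81.1%, a number higher than compound 1 beyond the scatter. The furthest is compound 2, which gives 87.1%, also beyond the scatter above compound 1. For the measured compounds named here, compound 2 and compound 3 each differ from compound 1 in more than one place, so no step between measured compounds that changes a single site is available.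

Compound 4, `COc1cc(NC(=O)Nc2cc(Nc3ccc(C)c(C)c3)ncn2)cc(OC)c1`, has not yet been measured. Its structure departs from compound 1 as follows: 3,4-dimethylphenyl in place of 3-iodo-4-methoxyphenyl on a nitrogen on an aromatic ring. Both groups occupy the same place on the shared core. Because compound 3 gives 81.1% and compound 2 gives 87.1%, both above compound 1 while carrying a different group at that nitrogen, a small rise is expected. The step from compound 1 to compound 4 is expected to be a number 8.9 percentage points higher from compound 1 to compound 4 (within the scatter), which may not exceed the scatter. Compound 4 is expected to give about 56% in this assay, with a range from 32% to 80%.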

Compound 4, a percentage reported as inhibition, at one concentration (the size of the read-out at that concentration, not a potency): 66%
Compound 4: middle estimate off by 10 percentage points, on the low side; low and high end bracket the measured number.
By their numbers in this assay, from the lowest: compound 1; then compound 4; then compounds 3 and 2 (each within the scatter of the next).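

In this assay, for the compounds shown here, putting 3,4-dimethylphenyl in place of 3-iodo-4-methoxyphenyl on a nitrogen on an aromatic ring gives the only single-site step available here, a change of a number 18.9 percentage points higher from compound 1 to compound 4 (beyond the scatter) on the shared core. Going by these compounds alone, this shows that this position alone can move the read-out beyond the scatter while the rest of compound 1 stays fixed, something the earlier compounds, which differ in more than one place, could not show. The entering group is carbon only and the leaving group holds iodine and oxygen, but nothing measured here accounts for the rise.

The step replaces both substituents on the ring at once, so the share of each remains unresolved. On these data alone, how an amine or a carboxylic acid on that ring would read also remains open.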